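The source may hold more compounds than are shown below. What is called first, only, known or untested is meant among the compounds shown, and "the series" means these compounds.

Compound 1 `CCCN1CC[C@H](NC(=O)C[C@@H]2C(=O)NC=CN2S(=O)(=O)c2ccc(C)cc2)C(C)(C)C1`: 0.51 nM
Compound 2 `Cc1ccc(S(=O)(=O)N2C=CNC(=O)[C@H]2CC(=O)N[C@H]2CCN(Cc3ccccc3)CC2(C)C)cc1`: 1.09 nM

In an in vitro functional assay on cells for antagonist activity at B1 bradykinin receptor (Homo sapiens), read by luminescence and calcium flux, with a stated time of 2 h (on this read-out higher numbers stand for weaker inhibition and lower numbers for stronger inhibition), compound 2 gives 1.09 nM, the higher of the two numbers, and compound 1 gives 0.51 nM; the step of a 2.1-fold higher number from compound 1 to compound 2 (0.33 log units; beyond the scatter) lies beyond the scatter, though it is modest. Compound 3 `Cc1ccc(S(=O)(=O)N2C=CNC(=O)[C@H]2CC(=O)N[C@H]2CCN(C3CCC3)CC2(C)C)cc1` differs from compound 2 by cyclobutyl in place of benzyl on an amine nitrogen in a ring. Among the measured compounds shown here, only that one measured step bears on this change, and it shows the saturated group of compound 1 and the aromatic group of compound 2 sitting close together. Compound 3 is therefore expected to give 0.7 nM, within a range of 0.3 nM to 2 nM. The expected step of a 1.6-fold lower number from compound 2 to compound 3 (0.19 log units; within the scatter) is small, toward a lower number, and may well fall within the scatter.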

Compound 3, half-maximal inhibitory concentration: 0.74 nM
Estimate against measurement, compound 3: 1.1-fold (0.02 log units) below, within the range that was stated.
By their numbers in this assay, from the lowest: compounds 1, 3 and 2 (each within the scatter of the next, the first and the last beyond it).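

Cyclobutyl in place of benzyl gives a 1.5-fold lower number from compound 2 to compound 3 (0.17 log units; within the scatter) in this assay, and cyclobutyl in place of propyl gives a 1.5-fold higher number from compound 1 to compound 3 (0.16 log units; within the scatter) on the same amine nitrogen in a ring. A small non-aromatic carbon ring at this position therefore cannot be told apart from either earlier group, even though compound 1 and compound 2 differ beyond the scatter. No measurement shown explains this result.

On these data alone, what a hydroxyethyl chain or a carboxylic acid on this nitrogen would give stays open. So does the effect of a longer chain there.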